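Moving the Ring One Carbon Out in Compound 4

The source may hold more compounds than are shown below. What is called first, only, known or untested is meant among the compounds shown, and "the series" means these compounds.

Of the compounds shown here, three sharing one core have been measured in an in vitro functional assay on cells for agonist activity at Bombesin receptor subtype-3 (Homo sapiens), read by luminescence and calcium flux; a higher number here means that more compound is needed for the effect, a lower number that less compound is needed. Compound 1 `O=C(O)c1ccccc1-c1ccc(CCc2ncc(Cc3cccc(Cl)c3)[nH]2)cc1` gives 825 nM. Compound 2 `COc1cccc(Cc2cnc(CCc3ccc(-c4ccccc4C(=O)O)cc3)[nH]2)c1` gives 4120 nM, and compound 3 `O=C(O)c1ccccc1-c1ccc(CCc2ncc(C3CCCCC3)[nH]2)cc1` gives 375 nM. Compound 3 thus has the lowest number of the three: the step of a 2.2-fold lower number from compound 1 to compound 3 (0.34 log units; beyond the scatter) and the step of an 11-fold lower number from compound 2 to compound 3 (1.04 log units; beyond the scatter) both favour it, while the step of a 5.0-fold higher number from compound 1 to compound 2 (0.70 log units; beyond the scatter) sets the two benzyl-bearing compounds apart from each other.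

Compound 4 `O=C(O)c1ccccc1-c1ccc(CCc2ncc(CC3CCCC3)[nH]2)cc1` is not yet measured. It differs from compound 3 by cyclopentylmethyl in place of cyclohexyl on an aromatic carbon; the two have the same atoms, joined differently. For the measured compounds named here, the steps that bear on this change are those from compound 1 and compound 2 to compound 3, in which a cyclohexyl attached directly to the aromatic carbon gave a lower number than groups reaching the ring through one extra carbon. Compound 4 again has one carbon between the aromatic ring and its non-aromatic ring, so a somewhat higher number than for compound 3 is expected, a 1.6-fold higher number from compound 3 to compound 4 (0.20 log units; within the scatter), though a step of this size could still fall within the scatter. Compound 4 is therefore estimated at 600 nM, with a range from 250 nM to 1500 nM.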

Compound 4, half-maximal effective concentration: 133 nM
Compound 4: the middle estimate sits 4.5-fold (0.65 log units) above what was measured; the whole stated range lies above it.
By their numbers in this assay, from the lowest: compound 4; then compound 3; then compound 1; then compound 2.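

In this assay, a carbon reaching out to the ring does not in itself bring a higher number: cyclopentylmethyl in place of cyclohexyl gives a 2.8-fold lower number from compound 3 to compound 4 (0.45 log units; beyond the scatter). On that same saturated chain carbon, cyclopentyl in place of the substituted phenyl rings gives a 6.2-fold lower number from compound 1 to compound 4 (0.79 log units; beyond the scatter) and a 31-fold lower number from compound 2 to compound 4 (1.49 log units; beyond the scatter), so the one-carbon link goes with the lowest number of the four when it carries a non-aromatic ring. Nothing shown explains these differences.

Ring size and linker remain unseparated: neither cyclohexylmethyl nor a directly attached cyclopentyl stands among these compounds. Also open, on these data alone, is how the number responds to a longer chain ahead of the cyclopentyl ring, or to an amine on it.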